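Benzamide series: naphthyl in place of methoxyphenyl

This account rests on a few compounds, and the source may have more. Where it says the series, first, only, none or still open, it means among the compounds named here.

Measured so far in a functional assay on SK-BR-3 cells (Homo sapiens) for antiproliferative activity, read by MTT assay, with a stated time of 48 h; on this read-out higher numbers stand for weaker inhibition and lower numbers for stronger inhibition:
compound 1 `COc1ccc(C(=O)Nc2ccc(N(C)S(C)(=O)=O)c(OCc3cc(C(F)(F)F)ccc3C)c2)cc1` gives 2030 nM
compound 2 `COc1ccc(OC)c(COc2cc(NC(=O)c3ccc(Br)cc3)ccc2N(C)S(C)(=O)=O)c1` gives 3.51 nM
compound 3 `COc1ccc(C(=O)Nc2ccc(N(C)S(C)(=O)=O)c(OCc3cc(OC)ccc3OC)c2)cc1` gives 2.56 nM

Compound 3 has the lowest number of the three. Its nearest neighbour is compound 2, separated by a 1.4-fold lower number from compound 2 to compound 3 (0.14 log units; within the scatter), a gap within the scatter, so the two cannot be ordered. Within the data shown here, compound 1 lies far off, separated by a 790-fold lower number from compound 1 to compound 3 (2.90 log units; beyond the scatter), which is beyond the scatter and is the only large step in the set; it concerns the benzylic ether side of the core, not the amide side.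

Compound 4 `COc1ccc(OC)c(COc2cc(NC(=O)c3ccc4ccccc4c3)ccc2N(C)S(C)(=O)=O)c1` differs from compound 3 only on the amide side: naphthalen-2-yl in place of 4-methoxyphenyl on a carbonyl carbon. Among the measured compounds shown here, the single step that bears on this position is the one from compound 2 to compound 3, where bromo was replaced by methoxy on the same aromatic ring with a change within the scatter. Nothing measured covers a second fused ring at this position, so the expectation rests on that one small step. The amide-side aryl appears tolerant of exchange between the two compounds measured there, so compound 4 is expected to show a step of a 1.4-fold higher number from compound 3 to compound 4 (0.14 log units; within the scatter), with no change beyond the scatter anticipated in this assay. Compound 4 is therefore estimated at 3.5 nM, within 1 nM to 12 nM.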

Compound 4, half-maximal inhibitory concentration: 16.6 nM
Compound 4: middle estimate off by 4.7-fold (0.68 log units), on the low side; the whole stated range lies below it.
By their numbers in this assay, from the lowest: compounds 3 and 2 (each within the scatter of the next); then compound 4; then compound 1.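

In this assay the aryl group on the carbonyl carbon proves less freely exchangeable than the single-ring pair suggested: naphthalen-2-yl in place of 4-methoxyphenyl gives (a 6.5-fold higher number from compound 3 to compound 4 (0.81 log units; beyond the scatter)), and naphthalen-2-yl in place of 4-bromophenyl gives (a 4.7-fold higher number from compound 2 to compound 4 (0.67 log units; beyond the scatter)). Both steps lie beyond the scatter and run the same way, whereas the exchange between the two single-ring groups stays within it (a 1.4-fold lower number from compound 2 to compound 3 (0.14 log units; within the scatter)), so this position does respond to the aryl group, though by far less than the ether side of the core does in the step (a 790-fold lower number from compound 1 to compound 3 (2.90 log units; beyond the scatter)). No supporting data bear on the reason for this shift.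

Still open, as far as these compounds go, is whether the higher number follows from the second fused ring itself or from the particular attachment at naphthalen-2-yl, which naphthalen-1-yl or a quinoline on the same carbonyl carbon could help separate. Also open, from the compounds shown here alone, is how far the position extends beyond aromatic carbon groups, for example a cyclohexyl ring, a longer alkyl chain, or a 4-aminophenyl or 4-carboxyphenyl group in place of 4-methoxyphenyl.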